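The source may report more compounds than this note shows. Statements on the series, on what has been measured and on what is new or still open speak of the compounds shown alone.

Compound 1 `O=c1[nH]nc2n(c1=O)CCN2c1ccccc1`: 0%
Compound 2 `Cc1ccc(N2CCn3c2n[nH]c(=O)c3=O)cc1`: 20%
Compound 3 `COc1ccccc1N1CCn2c1n[nH]c(=O)c2=O`: 0%

All three were tested in a functional assay on A549 cells (Homo sapiens) for antiproliferative activity, with a stated time of 72 h, tested at 10 ug/mL; a lower number here means a weaker effect, a higher number a stronger effect of the compound at the concentration tested. Compound 1 and compound 3 share the lowest reading of the set, with no change at the digits printed from compound 1 to compound 3 (within the scatter), while compound 2 stands above them, with a number 20 percentage points higher from compound 1 to compound 2 (beyond the scatter).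

Compound 4 `O=c1[nH]nc2n(c1=O)CCN2c1cccc(Cl)c1` has not been measured. It differs from compound 1 by chloro in place of hydrogen on an aromatic carbon. Among the compounds with values here, two measured steps bear on this, since each also puts a small group in place of a hydrogen on an aromatic carbon of the same ring: methyl, which gave a number 20 percentage points higher from compound 1 to compound 2 (beyond the scatter), and methoxy, which gave no change at the digits printed from compound 1 to compound 3 (within the scatter). One is a modest rise, the other no change beyond the scatter. Chloro itself has not been tried in this series, so the outcome is uncertain, and anything from no change to a modest rise seems plausible.

Compound 4 is therefore expected to give about 10%, with a likely range from 0% to 30%. The step this estimate implies is a number 10 percentage points higher from compound 1 to compound 4 (within the scatter).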

Compound 4, a percentage reported as inhibition, at one concentration (the size of the read-out at that concentration, not a potency): 0%
For compound 4 the middle estimate is 10 percentage points above the measured one; the range from low to high includes it.
By their numbers in this assay, from the lowest: compounds 1, 3 and 4 (each within the scatter of the next); then compound 2.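

Chloro, placed on an aromatic carbon meta to a large group, leaves the reading in this assay flat, with no change at the digits printed from compound 1 to compound 4 (within the scatter) as the step. Chloro therefore sides with methoxy rather than methyl, so among these three groups only methyl, with a number 20 percentage points higher from compound 1 to compound 2 (beyond the scatter) as its step, lifts the reading beyond the scatter, and placing just any small group on this ring is not enough to do so. No measurement shown here explains why the chloro and methyl steps differ.

Still open, on these data alone, is whether chloro would behave differently on another carbon of this ring, or methyl on the carbon that chloro occupies here. Also open, as far as these compounds go, is how a clearly different group on this ring, such as an amine or a carboxylic acid, would change the reading.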